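The source may report more compounds than this note shows. Statements on the series, on what has been measured and on what is new or still open speak of the compounds shown alone.

Measured compounds:
Compound 1, `CCCn1c(=O)[nH]c2nc(-c3ccc(S(=O)(=O)N4CCN(c5cccc(Cl)c5)CC4)cc3)[nH]c2c1=O`: 0.342 nM
Compound 2, `CCCn1c(=O)[nH]c2nc(-c3ccc(S(=O)(=O)N4CCN(c5ccc(C)cc5)CC4)cc3)[nH]c2c1=O`: 0.706 nM

In an assay on CHO cells for displacement of a labelled ligand from adenosine receptor A2b (Homo sapiens), read by scintillation counting, with a stated time of 75 min, in the presence of a further agent that is not named here (a higher number here means a weaker inhibitor, a lower number a stronger inhibitor), compound 1 gives 0.342 nM, while compound 2 gives 0.706 nM. Among the compounds with values here, compound 2 thus stands at the higher of the two numbers, the single measured step being a 2.1-fold higher number from compound 1 to compound 2 (0.31 log units; beyond the scatter). Compound 3, `CCCn1c(=O)[nH]c2nc(-c3ccc(S(=O)(=O)N4CCN(Cc5ccc(Br)c(F)c5)CC4)cc3)[nH]c2c1=O`, differs from compound 2 in one place: 4-bromo-3-fluorobenzyl in place of 4-methylphenyl on an amine nitrogen in a ring. Within the data shown here, no measured step bears directly on this change; the one available step exchanges one aryl group for another on the same ring nitrogen, whereas here a benzyl carrying bromine and fluorine enters. Among the measured compounds shown here, with only that modest step as a guide, the expectation for compound 3 is a number near that of compound 2, with a step of a 1.4-fold higher number from compound 2 to compound 3 (0.15 log units; within the scatter) expected but of uncertain direction. Compound 3 is therefore estimated at 1 nM, in a range from 0.25 nM to 4 nM.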

Compound 3, inhibition constant: 0.473 nM
For compound 3 the middle estimate is 2.1-fold (0.33 log units) above the measured one, and the stated range covers the measured number.
By their numbers in this assay, from the lowest: compounds 1, 3 and 2 (each within the scatter of the next, the first and the last beyond it).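

Placed on the amine nitrogen in the six-membered ring, a benzyl group carrying bromine and fluorine is the first non-phenyl group shown at this position. In this assay the change gives a 1.5-fold lower number from compound 2 to compound 3 (0.17 log units; within the scatter) and a 1.4-fold higher number from compound 1 to compound 3 (0.14 log units; within the scatter), so this position accepts the 4-bromo-3-fluorobenzyl group, with its two further heavy atoms, without a step beyond the scatter from either phenyl compound. Nothing available explains this result.

Within the data shown here, the single benzyl example does not separate any contribution of the bromine from that of the fluorine, or either from that of the benzyl group itself. As far as these compounds go, whether an unsubstituted benzyl, a pyridyl group or a longer chain ending in a phenyl ring would stay within this narrow range of values remains open.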